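Phenyl for trifluoromethyl on the amine ring

The compounds below may be only part of what the source reports. "The series", "measured", "known", "first", "only" and "open" are said of these compounds alone.

Three compounds of this series have numbers in an assay on CHO cells for displacement of a labelled ligand from 5-hydroxytryptamine receptor 7 (Homo sapiens); on this read-out lower numbers stand for stronger inhibition and higher numbers for weaker inhibition. Compound 1 `O=S(=O)(c1ccccc1)C1(CCCCN2CCC(c3ccccc3)C2)CCC1` gives 13 nM in this assay. Compound 2 `CC(C)(CCCN1CC[C@@H]2CCCC[C@H]2C1)S(=O)(=O)c1ccccc1` gives 8 nM in this assay. Compound 3 `CC(C)(CCCN1CCCC(C(F)(F)F)C1)S(=O)(=O)c1ccccc1` gives 54 nM in this assay, the highest number of the three: the gaps to compound 1 and to compound 2 both lie beyond the scatter, so compound 3 is the weakest binder among the measured set.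

Compound 4 `CC(C)(CCCN1CCCC(c2ccccc2)C1)S(=O)(=O)c1ccccc1` has not yet been measured in this assay. It differs from compound 3 in one place: phenyl in place of trifluoromethyl on a saturated ring carbon of the six-membered ring that carries the basic nitrogen. Among the measured compounds shown here, no measured pair shows this exact exchange. Compound 1 and compound 2, which carry a phenyl or a fused carbocycle on the amine ring, both sit well below compound 3, so a step toward lower numbers, beyond the scatter, is expected for the exchange from compound 3 to compound 4, of about a 4.5-fold lower number from compound 3 to compound 4 (0.65 log units; beyond the scatter). Compound 4 is therefore estimated at 12 nM in this assay, with a range from 4 nM to 40 nM.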

Compound 4, inhibition constant: 7 nM
Beside the measured number, compound 4's estimate is 1.7-fold (0.23 log units) above it, within the range that was stated.
By their numbers in this assay, from the lowest: compounds 4, 2 and 1 (each within the scatter of the next); then compound 3.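

In this assay, among the compounds shown here, the exchange of trifluoromethyl for phenyl on a saturated ring carbon, two ring bonds from the ring nitrogen, gives a 7.7-fold lower number from compound 3 to compound 4 (0.89 log units; beyond the scatter) and provides the first direct reading of this position with the rest of the molecule unchanged. The position accepts one six-membered aromatic ring of carbon only, six heavy atoms where four stood, and the number falls rather than rises. Nothing measured in this set accounts for the step.

The compounds shown leave open whether a cyclohexyl or a pyridyl group on this carbon would read like phenyl, and whether a methyl group would read like trifluoromethyl. As far as these compounds go, compound 3 and compound 4 are drawn without a stated configuration at this carbon, so the contribution of each mirror form also remains open.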